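This account rests on a few compounds, and the source may have more. Where it says the series, first, only, none or still open, it means among the compounds named here.

Measured so far: compound 1 `O=C(CN1C(=O)NC2(C1=O)c1ccccc1-c1ccccc12)Nc1ccc(Br)cc1` gives 81.1% in a functional assay on the whole organism (strain BALB/c) with Mus musculus as the target, with a stated time of 8 h, at a dose of 10 mg/kg; a lower number here means less inhibition, a higher number more inhibition at the dose given (going by the name of the read-out). Compound 2 `Cc1ccc(NC(=O)CN2C(=O)NC3(C2=O)c2ccccc2-c2ccccc23)cc1` gives 53.4% in this assay. Compound 3 `COc1ccc(NC(=O)CN2C(=O)NC3(C2=O)c2ccccc2-c2ccccc23)cc1` gives only a limit of the assay in this assay, <= 200%, as the limit of <= 200% in this assay, at which 1 of the 3 values shown sits, records.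

Among the two readable numbers, compound 2 stands lowest; the step of a number 27.7 percentage points lower from compound 1 to compound 2 (beyond the scatter) came with methyl in place of bromo on an aromatic carbon. Compound 4 `O=C(CN1C(=O)NC2(C1=O)c1ccccc1-c1ccccc12)Nc1ccc(Cl)cc1Cl` carries the change (2,4-dichlorophenyl in place of 4-methylphenyl on an amide-type nitrogen). Within the data shown here, only that one measured step bears on it, and it points to halogen on the ring giving more inhibition than methyl, so a step up is expected, a number 20.6 percentage points higher from compound 2 to compound 4 (beyond the scatter). Compound 4 is therefore estimated at 74%, between 48% and 95%.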

Compound 4, a percentage reported as inhibition, in the whole organism at one dose (the size of the read-out at that dose, not a potency): 84.3%
Estimate against measurement, compound 4: 10.3 percentage points below, and the stated range covers the measured number.
By their numbers in this assay, from the lowest: compound 2; then compounds 1 and 4 (each within the scatter of the next).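

On the amide-type nitrogen, 2,4-dichlorophenyl in place of 4-methylphenyl gives a number 30.9 percentage points higher from compound 2 to compound 4 (beyond the scatter), so a second halogen-bearing ring now stands clear of the methyl compound. Against 4-bromophenyl, the same position gives a number 3.2 percentage points higher from compound 1 to compound 4 (within the scatter), so a single bromo and two chloro groups are not told apart here. Compound 3 has only a limit, and its step to compound 4 cannot be read: the limit of <= 200% in this assay, at which 1 of the 4 values shown sits.

As far as these compounds go, whether a ring carrying an amine or a carboxylic acid would hold this level stays open. So does the outcome for a longer alkyl chain in place of the ring.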